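The source may hold more compounds than are shown below. What is called first, only, known or untested is meant among the compounds shown, and "the series" means these compounds.

Compound 1 `CNC(=O)/C=C/c1ccncc1-c1ccc2ccccc2c1` was tested in a functional assay on KB cells (Homo sapiens) for inhibition, read by sulforhodamine B assay, with a stated time of 72 h; a higher number here means a weaker inhibitor of growth, a lower number a stronger inhibitor of growth. In this assay compound 1 gives only > 10000 nM, which is a limit of the assay rather than a number. Compound 2 `O=C(O)/C=C/c1ccncc1-c1ccc2cc[nH]c2c1` also gives only the limit > 10000 nM in this assay. Compound 3 `CNC(=O)/C=C/c1ccncc1-c1ccc2c(ccn2C)c1` gives 7080 nM in this assay. Compound 1 therefore stands at the limit of > 10000 nM in this assay, at which 2 of the 3 values shown sit, with no numbered value of its own. Compound 4 `O=C(/C=C/c1ccncc1-c1ccc2ccccc2c1)NC1CC1` differs from compound 1 by cyclopropyl in place of methyl on an amide-type nitrogen, methylcarbamoyl becoming cyclopropylcarbamoyl. Within the data shown here, no measured step of this kind is available here. For compound 4 the expected step is a number no higher from compound 1 to compound 4 (the limit leaves the size open), a change not beyond the usual scatter. Compound 4 is therefore estimated at 10000 nM, with a range from 3000 nM to 30000 nM, and a good chance that only a limit is again reported.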

Compound 4, concentration for 50% growth inhibition: 6050 nM
For compound 4 the middle estimate is 1.7-fold (0.22 log units) above the measured one; low and high end bracket the measured number.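

On the core of compound 1, the cyclopropylcarbamoyl group gives a numbered value in this assay: compound 4 reaches 6050 nM. On these data alone, the change reads as an at least 1.6-fold lower number from compound 1 to compound 4 (0.21 log units; that floor lies within the scatter), so this amide-type nitrogen carries cyclopropyl with no loss, but the real size of the step stays unknown. Compound 1 itself remains only a limit, not a number: the limit of > 10000 nM in this assay, at which 2 of the 4 values shown sit.

The compounds shown leave open how a longer chain, a hydroxyethyl group or an amine on this nitrogen would read. They also leave open whether cyclopropyl in place of methyl gives a similar result on the core of compound 3.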